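The compounds below may be only part of what the source reports. "The series", "measured", "known", "first", "only" and "open" are said of these compounds alone.

Measured so far in an ADME assay on L02 cells (Homo sapiens) for antiproliferative activity, read by MTT assay, with a stated time of 48 h; on this read-out higher numbers stand for weaker inhibition and lower numbers for stronger inhibition:
Compound 1 `CC(=O)Nc1ccc(-n2nncc2CN2C(=O)C3(C(C#N)=C(N)Oc4c3c3nc5ccccc5nc3c3ccccc43)c3ccccc32)cc1`: > 50000 nM, a limit of the assay rather than a number.
Compound 2 `CCc1ccccc1-n1nncc1CN1C(=O)C2(C(C#N)=C(N)Oc3c(N)cc4nc5ccccc5nc4c32)c2ccccc21`: 22900 nM.

Going by the values given here, compound 2 thus carries the only numerical value in this assay. The result for compound 1 is a limit only, and (the limit of > 50000 nM in this assay, at which 1 of the 2 values shown sits). Compound 3 `COc1ccc(-n2nncc2CN2C(=O)C3(C(C#N)=C(N)Oc4c(N)cc5nc6ccccc6nc5c43)c3ccccc32)cc1` has not yet been measured. It differs from compound 2 in one place: 4-methoxyphenyl in place of 2-ethylphenyl on an aromatic nitrogen. Among the compounds with values here, no measured pair shows an exchange of this kind, so nothing fixes its size. The change is expected to shift the value little, a 1.3-fold higher number from compound 2 to compound 3 (0.12 log units; within the scatter), with no direction beyond the scatter. Compound 3 is therefore estimated at 30000 nM, within the range 12000 nM to 70000 nM.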

Compound 3, half-maximal inhibitory concentration: > 50000 nM
Compound 3: only a limit was reported; the forecaster's own chance of this, stated with the estimate: 35%; middle value at least 1.6-fold (0.22 log units) away from the limit.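

In this assay, the group on the aromatic nitrogen does matter: 4-methoxyphenyl in place of 2-ethylphenyl gives an at least 2.1-fold higher number from compound 2 to compound 3 (0.33 log units; beyond the scatter). For compound 3 this step rests on a limit of the assay, not on a number. The full size of the step therefore stays unknown: the limit of > 50000 nM in this assay, at which 2 of the 3 values shown sit.

The two groups differ both in their substituent and in where it sits on the phenyl ring, so 2-methoxyphenyl or 4-ethylphenyl would be needed to separate these two features. Going by these compounds, how plain phenyl or an aminophenyl would read here also remains open.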